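This account rests on a few compounds, and the source may have more. Where it says the series, first, only, none or still open, it means among the compounds named here.

In an ADME assay on a cell-free system (plasma, Homo sapiens) for metabolic stability, read by HPLC, tested at 5 mM (a lower number here means that the compound disappears faster, a higher number that the compound lasts longer), compound 2 `C[C@@H](O)[C@H]1C(=O)N2C(C(=O)OCOC(=O)OC3CCCc4ccccc4C3)=C(S[C@@H]3CN[C@H](C(=O)N(C)C)C3)[C@H](C)[C@H]12` gives 0.383 h as its half-life. That is the higher of the two single numbers available, the other being the 0.0717 h of compound 1 `C[C@@H](O)[C@H]1C(=O)N2C(C(=O)OCOC(=O)OC3Cc4ccccc4C3)=C(S[C@@H]3CN[C@H](C(=O)N(C)C)C3)[C@H](C)[C@H]12` in the same test. Compound 3 `CC(C)OC(=O)OC(C)OC(=O)C1=C(S[C@@H]2CN[C@H](C(=O)N(C)C)C2)[C@H](C)[C@@H]2[C@@H]([C@@H](C)O)C(=O)N12` has no single number: its two entries (0.183 h; 1.8 h (2 entries)) sit on either side of the value for compound 2 and disagree widely with each other.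

Compound 4 `C[C@@H](O)[C@H]1C(=O)N2C(C(=O)OCOC(=O)O[C@@H]3CCCCc4ccccc43)=C(S[C@@H]3CN[C@H](C(=O)N(C)C)C3)[C@H](C)[C@H]12` has the same atoms as compound 2, joined differently: a group of 11 heavy atoms (11 carbon; one six-membered aromatic ring of carbon only, one seven-membered non-aromatic ring of carbon only) in place of a group of 11 heavy atoms (11 carbon; one six-membered aromatic ring of carbon only, one seven-membered non-aromatic ring of carbon only), on an oxygen next to a carbonyl group is the whole change, made on an oxygen next to a carbonyl group, and the new group has a defined stereocentre.

For the measured compounds named here, only one measured step bears on this place, a 5.3-fold higher number from compound 1 to compound 2 (0.73 log units; beyond the scatter) and it is modest. That step altered the size of the group, whereas here the atom count stays the same and only the joining differs. No direction can be read from it, so the expected step, a 1.1-fold lower number from compound 2 to compound 4 (0.04 log units; within the scatter) is estimated to stay within the scatter. The disagreement between the entries for compound 3 (0.183 h; 1.8 h (2 entries)) argues for a wide range. Compound 4 is estimated at 0.35 h with 0.1 h to 1.2 h as the expected range in this assay for now.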

Compound 4, half-life: 0.567 h
Compound 4: middle estimate off by 1.6-fold (0.21 log units), on the low side, within the range that was stated.
By their numbers in this assay, from the lowest: compound 1; then compounds 2 and 4 (each within the scatter of the next).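

Joining the same atoms differently on the oxygen gives a 1.5-fold higher number from compound 2 to compound 4 (0.17 log units; within the scatter) in this assay, so the new arrangement and its defined stereocentre do not separate these two compounds. The comparison with the smaller group of compound 1, which has a five-membered non-aromatic ring, gives a 7.9-fold higher number from compound 1 to compound 4 (0.90 log units; beyond the scatter), so both groups described as having a seven-membered non-aromatic ring now stand clear of compound 1 in this assay. Small gaps between compounds call for caution, because a single compound can return widely differing entries: the several entries of compound 3 in this assay, 0.183 h; 1.8 h (2 entries).

The compounds shown do not separate the effect of the defined stereocentre in compound 4 from that of the new way the ring atoms are joined. On these data alone, it also remains open how the half-life in this assay would respond if a simple longer carbon chain took the place of the ring group on this oxygen, or if an amine or a carboxylic acid were attached to that group.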